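The source may report more compounds than this note shows. Statements on the series, on what has been measured and on what is new or still open speak of the compounds shown alone.

Measured in a functional assay on HUVEC cells (Homo sapiens), read by BrdU incorporation, with a stated time of 72 h; a lower number here means a stronger inhibitor, a higher number a weaker inhibitor:
- Compound 1 `Cc1cc(C(=O)/C=C/c2cc3cccc(C)c3nc2Cl)c(C)s1`: "not determined" (no result reported)
- Compound 2 `Cc1cccc2cc(/C=C/C(=O)c3ccc(I)s3)c(Cl)nc12`: 284 nM
- Compound 3 `Cc1ccc2nc(Cl)c(/C=C/C(=O)c3cc(C)sc3C)cc2c1`: 229 nM

Compound 3 has one numerical neighbour, compound 2, and their two values lie within the scatter of each other. Compound 1 offers no number for comparison.

Compound 4 `Cc1ccc2nc(Cl)c(/C=C/C(=O)c3sccc3Br)cc2c1` carries 3-bromothiophen-2-yl in place of 2,5-dimethylthiophen-3-yl on a carbonyl carbon. Among the measured compounds shown here, no measured pair isolates this exchange, so the expectation is loose. Compound 2, which also has a halogen on its thiophene, gives 284 nM. In this assay, the expected step of a 1.2-fold higher number from compound 3 to compound 4 (0.09 log units; within the scatter) stays within the scatter. For compound 4 the estimated value is 280 nM, with an expected range of 95 nM to 850 nM.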

Compound 4, half-maximal inhibitory concentration: 61.9 nM
The estimate for compound 4 lay 4.5-fold (0.66 log units) above the measured number, and the stated range ends above it.
By their numbers in this assay, from the lowest: compound 4; then compounds 3 and 2 (each within the scatter of the next).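

In this assay, the group on the carbonyl carbon clearly affects the result: 3-bromothiophen-2-yl in place of 2,5-dimethylthiophen-3-yl gives a 3.7-fold lower number from compound 3 to compound 4 (0.57 log units; beyond the scatter). Until now, no step between compounds differing in one place had shown this. No measured evidence here explains the step.

The exchange removes both methyl groups, adds a bromine and changes how the thiophene is attached, so the contribution of each change remains unresolved. Also open, from the compounds shown here alone, is how a phenyl ring or a thiophene bearing an amine would behave on this carbonyl carbon.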